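Dimethylamino in place of bromo in an acyclic nucleoside set

The source may hold more compounds than are shown below. What is called first, only, known or untested is meant among the compounds shown, and "the series" means these compounds.

Working notes on a small set of acyclic nucleoside analogues tested in a functional assay on L1210 cells (Mus musculus) for inhibition; on this read-out higher numbers stand for weaker inhibition and lower numbers for stronger inhibition. Compound 1 `OCCOCn1cnc2c(O)ncnc21` reaches only the limit of the assay, > 1000 ug/mL, which is not a number. For the measured compounds named here, compound 2 `Nc1nc2c(nc(Br)n2COCCO)c(=O)[nH]1` gives 355 ug/mL in this assay and is therefore the only compound of the set with an actual number. The other value, that of compound 1, is the limit of > 1000 ug/mL in this assay, at which 1 of the 2 values shown sits. Going by the values given here, no measured pair differs in a single place, so no measured step is available to calibrate the change. Compound 3 `CN(C)c1nc2c(=O)[nH]c(N)nc2n1COCCO` has not yet been measured in this assay; it differs from compound 2 as follows: dimethylamino in place of bromo on an aromatic carbon. With nothing measured to lean on, the expected step is a 1.7-fold higher number from compound 2 to compound 3 (0.23 log units; within the scatter), no larger than the usual scatter in either direction, with a fair chance that only a limit is returned. Compound 3 is thus estimated at 600 ug/mL, within a range from 150 ug/mL to 1500 ug/mL.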

Compound 3, concentration for 50% inhibition: > 500 ug/mL
Compound 3 was reported as a limit; the forecaster's own chance of this, stated with the estimate: 45%; the middle value lies beyond the limit too.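

Compound 3 gives no number in this assay, only a limit: the limit of > 500 ug/mL in this assay, at which 1 of the 3 values shown sits.

Dimethylamino in place of bromo on this aromatic carbon, between two ring nitrogen atoms, gives an at least 1.4-fold higher number from compound 2 to compound 3 (0.14 log units; that floor lies within the scatter). For the compounds shown here, this is the first single-place change read, and it offers no sign of stronger inhibition with dimethylamino at this position, although its floor does not establish weaker inhibition and the true size of the step remains unknown.

Still open, on these data alone, is how far compound 3 lies past its limit, which a number from a wider concentration range would settle. Also open, as far as these compounds go, is whether a plain amino group or a chloro group on the same carbon would read close to compound 2, which would show whether the outcome is specific to dimethylamino.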